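The source may report more compounds than this note shows. Statements on the series, on what has been measured and on what is new or still open speak of the compounds shown alone.

Measured to date:
compound 1 `Oc1cccc(-c2cc(-c3ccccc3F)cc(-c3ccccc3O)n2)c1` 31100 nM
compound 2 `Oc1cccc(-c2cc(-c3ccccc3C(F)(F)F)cc(-c3ccccc3O)n2)c1` 16800 nM
compound 3 `Oc1ccccc1-c1cc(-c2ccccc2OC(F)(F)F)cc(-c2ccccc2O)n1` 9750 nM

All three numbers come from a functional assay on HeLa cells (Homo sapiens) for inhibition; a lower number here means a stronger inhibitor, a higher number a weaker inhibitor. Compound 3 gives 9750 nM in this assay, a number that is within the scatter of what compound 2 gives, 16800 nM. Compound 1 gives 31100 nM. The gap from compound 1 to compound 3 lies beyond the scatter. Going by the values given here, the only step between measured compounds that differ in one place is a 1.9-fold lower number from compound 1 to compound 2 (0.27 log units; within the scatter), and that step concerns the substituent on the third aryl group, not the hydroxyphenyl groups.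

Compound 4 is `Oc1cccc(-c2cc(-c3ccccc3OC(F)(F)F)cc(-c3ccccc3O)n2)c1`. It differs from compound 3 by 3-hydroxyphenyl in place of 2-hydroxyphenyl on an aromatic carbon. Among the compounds with values here, no measured pair isolates this change: compounds 1 and 2 carry a 3-hydroxyphenyl group, compound 3 carries two 2-hydroxyphenyl groups, and the third aryl substituent differs between them at the same time. Within the data shown here, there is therefore no measured step of the same kind to draw on, and no direction can be read from the data.

The expectation for compound 4 in this assay is a number close to that of compound 3, with no step beyond the scatter: a 1.1-fold higher number from compound 3 to compound 4 (0.05 log units; within the scatter) is the estimated step. Compound 4 is estimated at 11000 nM, with a range from 4000 nM to 30000 nM.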

Compound 4, half-maximal inhibitory concentration: 15200 nM
Compound 4: the middle estimate sits 1.4-fold (0.14 log units) below what was measured; low and high end bracket the measured number.
By their numbers in this assay, from the lowest: compounds 3, 4, 2 and 1 (each within the scatter of the next, the first and the last beyond it).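

In this assay, the exchange of 2-hydroxyphenyl for 3-hydroxyphenyl on the aromatic carbon next to the ring nitrogen now has a measured step of its own, a 1.6-fold higher number from compound 3 to compound 4 (0.19 log units; within the scatter), and the two isomers are not separated at this position. With the 3-hydroxyphenyl group held constant, the third aryl substituent gains two further steps: a 1.1-fold lower number from compound 2 to compound 4 (0.04 log units; within the scatter) for trifluoromethoxy in place of trifluoromethyl, which does not separate those two groups, and a 2.0-fold lower number from compound 1 to compound 4 (0.31 log units; beyond the scatter) for trifluoromethoxy in place of fluoro, which is modest. Going by these compounds alone, of the new steps, only the one concerning the third aryl substituent clears the scatter, while the one concerning the hydroxyphenyl group does not.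

The compounds shown leave open whether the same hydroxyphenyl exchange behaves alike with fluoro or trifluoromethyl on the third aryl group. They also leave open how the number responds when the hydroxyl of either hydroxyphenyl group gives way to an amine or a carboxylic acid.

No measurement to hand offers a reason for any of these steps.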